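The source may report more compounds than this note shows. Statements on the series, on what has been measured and on what is new or still open speak of the compounds shown alone.

Compound 1, `Cc1cccc(NS(=O)(=O)c2cccc(CCCCCCNC(=O)/C=C/c3cccnc3)c2)c1`, gives in an assay on isolated protein for inhibition of Nicotinamide phosphoribosyltransferase (Homo sapiens), read by WST assay, with stated times of 60 min, 5 min and 30 min, in the presence of a further agent that is not named here (a lower number here means a stronger inhibitor, a higher number a weaker inhibitor), a value of 12.3 nM.
Compound 2, `CCc1ccc(NS(=O)(=O)c2cccc(CCCCCCNC(=O)/C=C/c3cccnc3)c2)cc1`, gives in this assay a value of 31.5 nM.

Among the measured compounds shown here, of the two numbers measured in this assay, compound 2 holds the higher one; its only neighbour is compound 1, and the step of a 2.6-fold higher number from compound 1 to compound 2 (0.41 log units; beyond the scatter) puts the two apart beyond the usual scatter. Compound 3, `O=C(/C=C/c1cccnc1)NCCCCCCc1cccc(S(=O)(=O)Nc2ccc(Cl)cc2)c1`, has not been measured. It differs from compound 2 by chloro in place of ethyl on an aromatic carbon. For the measured compounds named here, no measured step changes the same substituent, so the one measured step, from a 3-methylphenyl to a 4-ethylphenyl on the sulfonamide nitrogen, bears on it only loosely, showing that a change on this ring can shift the number modestly. The expectation for compound 3 in this assay is therefore a small step, a 1.3-fold lower number from compound 2 to compound 3 (0.10 log units; within the scatter), not clearly beyond the scatter in either direction. Compound 3 is estimated at 25 nM, within a range from 10 nM to 70 nM.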

Compound 3, half-maximal inhibitory concentration: 10.8 nM
The estimate for compound 3 lay 2.3-fold (0.36 log units) above the measured number; low and high end bracket the measured number.
By their numbers in this assay, from the lowest: compounds 3 and 1 (each within the scatter of the next); then compound 2.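

Compounds 1 and 2 differ in both the group and its place on the ring, whereas this pair changes only the group: in this assay, with the place held para to a large group, ethyl to chloro gives a 2.9-fold lower number from compound 2 to compound 3 (0.46 log units; beyond the scatter) and so moves the number beyond the scatter. The 4-chlorophenyl and 3-methylphenyl groups on the sulfonamide nitrogen stand level, with a 1.1-fold lower number from compound 1 to compound 3 (0.06 log units; within the scatter) within the scatter, which leaves the 4-ethylphenyl of compound 2 apart from both. No measured evidence here explains the difference between ethyl and chloro.

On these data alone, whether a methoxy, fluoro or trifluoromethyl group at this place would fall with chloro or with ethyl remains open. So does the effect of an amine or a carboxylic acid on this ring.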